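This account rests on a few compounds, and the source may have more. Where it says the series, first, only, none or still open, it means among the compounds named here.

Compound 1 `CONC(=O)c1ccccc1` and compound 2 `CONC(=O)c1ccccc1OC` share one core, and compound 2 carries methoxy in place of hydrogen on an aromatic carbon. In an ADME assay on Huh-7 cells (Homo sapiens) for cytotoxicity, read by MTT assay, with a stated time of 72 h (a higher number here means that more compound is tolerated, a lower number that less compound is tolerated), compound 1 gives > 800000 nM, which is a limit of the assay rather than a number. Compound 2 also gives > 800000 nM, likewise a limit. The step that the two limits leave unreadable from compound 1 to compound 2 cannot be read because of the limit of > 800000 nM in this assay, at which 2 of the 3 values shown sit. Compound 3 `Cc1cccc(C(=O)NO)c1` has a core whose difference from the core of compound 1 is not broken down here; in this assay compound 3 gives 340000 nM. Compound 4 `COc1ccc(C)cc1C(=O)NO` is not yet measured and differs from compound 3 by methoxy in place of hydrogen on an aromatic carbon. This is the same kind of change as from compound 1 to compound 2, though here the place is ortho to a hydroxycarbamoyl group and para to a methyl group rather than ortho to a group of 5 heavy atoms. With no readable size from that earlier step, compound 4 is expected to stay near compound 3, an estimated step of a 1.2-fold higher number from compound 3 to compound 4 (0.07 log units; within the scatter). The estimate for compound 4 in this assay is 400000 nM, between 150000 nM and 900000 nM.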

Compound 4, half-maximal cytotoxic concentration: 800000 nM
For compound 4 the middle estimate is 2.0-fold (0.30 log units) below the measured one, and the stated range covers the measured number.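

In this assay, methoxy in place of hydrogen on an aromatic carbon gives a 2.4-fold higher number from compound 3 to compound 4 (0.37 log units; beyond the scatter), so on this core the change goes with more compound being tolerated. The step from compound 1 to compound 2 cannot be read, and the reason is this: the limit of > 800000 nM in this assay, at which 2 of the 4 values shown sit. Going by these compounds alone, the one readable step therefore describes only the core of compound 3, and it does not show that the change carries over to the core of compound 1.

Still open, from the compounds shown here alone, is how an amine, a hydroxyl or an ethoxy group in that same place on the core of compound 3 would compare with methoxy. Also open, going by these compounds, is what methoxy does on any further core whose values stay clear of that limit.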